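Trimming the Sulfonyl Group: Isopropyl to Ethyl

The source may hold more compounds than are shown below. What is called first, only, known or untested is meant among the compounds shown, and "the series" means these compounds.

Of the compounds shown here, three with a shared core have been tested in an ADME assay on HEp-2 cells (Homo sapiens) for cytotoxicity; on this read-out higher numbers stand for lower toxicity in this test and lower numbers for higher toxicity in this test. Compound 1 `CC(C)S(=O)(=O)n1c(=O)n(Cc2nc3ccccc3n2CCCC#N)c2cnccc21` gives only a limit in this assay, > 228000 nM. Compound 3 `CC(C)(C)n1c(=O)n(Cc2nc3ccccc3n2CCCC#N)c2cnccc21` likewise gives only a limit, > 86800 nM. The step that the two limits leave unreadable from compound 1 to compound 3 is therefore unreadable. Going by the values given here, compound 2 `CC(C)S(=O)(=O)CCCn1c(Cn2c(=O)n(C3CC3)c3ccncc32)nc2ccccc21` is the one compound with a number: in this assay compound 2 gives 49200 nM. That is the only number shown, since the others sit at the limit of > 228000 nM in this assay, at which 1 of the 3 values shown sits, and at the limit of > 86800 nM in this assay, at which 1 of the 3 values shown sits.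

Compound 4 `CCS(=O)(=O)CCCn1c(Cn2c(=O)n(C3CC3)c3ccncc32)nc2ccccc21` differs from compound 2 by one change: hydrogen in place of methyl on a saturated chain carbon bound to a saturated chain carbon and a sulfonyl sulfur, so that isopropylsulfonyl becomes ethylsulfonyl. Among the compounds with values here, no measured step covers this change; the only measured step, tert-butyl in place of isopropylsulfonyl on an aromatic nitrogen, cannot be read between its two limits. With no evidence pointing either way, no step beyond the scatter is expected. Compound 4 is therefore estimated at 50000 nM in this assay, between 18000 nM and 140000 nM, an expected step of a 1.0-fold higher number from compound 2 to compound 4 (0.01 log units; within the scatter).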

Compound 4, half-maximal cytotoxic concentration: > 227000 nM
Compound 4 gave a limit, no number; the forecaster's own chance of this, stated with the estimate: 25%; middle value at least 4.5-fold (0.65 log units) away from the limit.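

Going by these compounds alone, until now no step could be read in this assay, and this is the first: hydrogen in place of methyl, which turns isopropylsulfonyl into ethylsulfonyl, gives an at least 4.6-fold higher number from compound 2 to compound 4 (0.66 log units; beyond the scatter), and on this read-out a higher number stands for lower toxicity in this test. This saturated chain carbon bound to the sulfonyl sulfur is therefore a sensitive place, since losing a single methyl, with no ring, hydrogen-bond donor, hydrogen-bond acceptor or net charge involved, moves the result beyond the scatter. Compound 4 gives a limit and not a number: the limit of > 227000 nM in this assay, at which 1 of the 4 values shown sits.

On these data alone, the true size of the step therefore stays open, as does whether it would hold on another core. Also open, as far as these compounds go, is where methylsulfonyl, or a longer chain such as propylsulfonyl, would fall in this assay.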